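Tolerated concentration along two amide-chain homologue pairs

The compounds below may be only part of what the source reports. "The series", "measured", "known", "first", "only" and "open" are said of these compounds alone.

Compound 1 `CCN(CC)c1nc(C)c2[nH]c(SCC(=O)NCCN)nc2n1` and compound 2 `CCN(CC)c1nc(C)c2[nH]c(SCC(=O)NCCCN)nc2n1` share one core, while compound 3 `CCN(CC)c1nc(C)c2[nH]c(SCC(=O)NCCN)[n+](CCCN(C)C)c2n1` and compound 4 `CCN(CC)c1nc(C)c2[nH]c(SCC(=O)NCCCN)[n+](CCCN(C)C)c2n1` share another; the difference between the two cores is not broken down here. In an ADME assay on CEM174 cells (Homo sapiens) for cytotoxicity (a lower number here means that less compound is tolerated, a higher number that more compound is tolerated), compound 1 gives > 100 uM, which is a limit of the assay and not a number. Compound 2 in this assay gives > 100 uM, again a limit. Compound 3 in this assay gives > 100 uM, also a limit. The change from compound 1 to compound 2 is aminomethyl in place of amino on a saturated chain carbon, two bonds along the chain from an amide-type nitrogen, and its step that the two limits leave unreadable from compound 1 to compound 2 cannot be read because of the limit of > 100 uM in this assay, at which 3 of the 3 values shown sit. The change from compound 3 to compound 4 is aminomethyl in place of amino on a saturated chain carbon, two bonds along the chain from an amide-type nitrogen, the same change at the same place. The step that the limit leaves unreadable from compound 3 to compound 4 expected for compound 4 is therefore placed as unreadable too, resting on the fact that the earlier step was hidden because of the limit of > 100 uM in this assay, at which 3 of the 3 values shown sit. In this assay compound 4 is expected to give 150 uM, most probably reported as a limit once more, with a range from 60 uM to 400 uM.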

Compound 4, half-maximal toxic concentration: > 100 uM
Compound 4 ended at the assay's limit (the forecaster's own chance of this, stated with the estimate: 85%); the middle value does not contradict the limit.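

No step can be read from compound 3 to compound 4, nor any other step in the series, because every value sits at a limit of the assay: the limit of > 100 uM in this assay, at which 4 of the 4 values shown sit.

The compounds shown leave open what concentration each of them actually tolerates in this assay, and whether aminomethyl in place of amino changes it on either core.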